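Adding a branch to the linker of compound 3

The source may report more compounds than this note shows. Statements on the series, on what has been measured and on what is new or still open speak of the compounds shown alone.

Three compounds share one amide-linked core and were tested in an assay on isolated protein for inhibition of cathepsin S (Homo sapiens); on this read-out lower numbers stand for stronger inhibition and higher numbers for weaker inhibition. Compound 1 `Cc1cccc(C(=O)N[C@@H](CC(C)C)C(=O)NCCNc2ccc(F)cc2)c1` gives 563 nM. Compound 2 `Cc1cccc(C(=O)N[C@@H](CC(C)C)C(=O)NCCN2CCc3cc(Cl)ccc32)c1` gives 196 nM. Compound 3 `COc1cccc(C(=O)N[C@@H](CCC2CCCCC2)C(=O)NCCN2CCc3cc(F)ccc32)c1` gives 2130 nM, the highest of the three numbers, which means the weakest inhibition: compound 1 sits nearer to it and compound 2 furthest away. Among the compounds with values here, the one step that can be compared directly, a 2.9-fold lower number from compound 1 to compound 2 (0.46 log units; beyond the scatter), concerns the ring at the far end of the chain and is modest in size.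

Compound 4 `COc1cccc(C(=O)N[C@@H](CCC2CCCCC2)C(=O)N[C@H](CN2CCc3cc(F)ccc32)C(C)C)c1` has not yet been measured. It differs from compound 3 by isopropyl in place of hydrogen on a saturated chain carbon bound to an amide-type nitrogen and a saturated chain carbon. Within the data shown here, none of the measured steps touches this part of the molecule, so nothing among the known numbers speaks directly to the change. On that basis the expected step is a 1.4-fold lower number from compound 3 to compound 4 (0.15 log units; within the scatter), that is, no change beyond the scatter is expected, with a wide range to reflect the lack of a comparable precedent. Compound 4 is therefore estimated at 1500 nM, between 400 nM and 6000 nM.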

Compound 4, inhibition constant: 14 nM
Compound 4: middle estimate off by 110-fold (2.03 log units), on the high side; the whole stated range lies above it.
By their numbers in this assay, from the lowest: compound 4; then compound 2; then compound 1; then compound 3.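

In this assay, within the data shown here, putting isopropyl in place of hydrogen on a saturated chain carbon bound to an amide-type nitrogen and a saturated chain carbon gives a 150-fold lower number from compound 3 to compound 4 (2.18 log units; beyond the scatter), so a part of the linker that none of the earlier steps touched has a very strong effect on this read-out. This single change, which adds no ring, no hydrogen-bond donor or acceptor and no net charge, is much larger than the change at the far end of the chain, a 2.9-fold lower number from compound 1 to compound 2 (0.46 log units; beyond the scatter), and it turns the compound with the highest number into the one with the lowest. No measurement available here bears on why the number falls so far.

As far as these compounds go, whether a methyl, a tert-butyl or a hydroxymethyl group on this carbon would act in the same way remains open. So does whether isopropyl would have a similar effect on compound 1 or compound 2, which differ from compound 3 elsewhere in the molecule.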